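The compounds below may be only part of what the source reports. "The series", "measured", "known", "first", "only" and "open" are said of these compounds alone.

Measured compounds in an ADME assay for permeability, using PAMPA, with a stated time of 30 min, at pH 7.4; a higher number here means that the compound crosses the layer faster, a lower number that the compound crosses the layer more slowly:
- compound 1 `COc1ccccc1Oc1ccc2c(NCCCNCc3ccco3)ccnc2c1` gives 317 10^-6 cm/s
- compound 2 `COc1cccc(CNCCCNc2ccnc3cc(Cc4ccccc4)ccc23)c1O` gives 23 10^-6 cm/s
- compound 3 `COc1ccc(F)cc1CNCCCNc1ccnc2cc(CC(C)C)ccc12` gives 23 10^-6 cm/s

Compound 2 stands at the bottom of the three numbers in this assay, level with compound 3 at the digits shown, the two lying within the scatter of each other. Compound 1 stands furthest away, at a number that is beyond the scatter above compound 2. Going by the values given here, no two of the measured compounds differ in only one place, so no single step has been measured.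

Compound 4 `COc1cccc(CNCCCNc2ccnc3cc(-c4ccccc4)ccc23)c1O` has not yet been measured in this assay. It differs from compound 2 as follows: phenyl in place of benzyl on an aromatic carbon. Among the compounds with values here, nothing among the measured compounds isolates this change, so the expectation rests on compound 2 alone. A step of no more than the usual scatter is expected in either direction, so for compound 4 the estimate is 25 10^-6 cm/s with a range of 10 10^-6 cm/s to 60 10^-6 cm/s. The expected step from compound 2 to compound 4 is accordingly a 1.1-fold higher number from compound 2 to compound 4 (0.04 log units; within the scatter).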

Compound 4, apparent permeability: 237 10^-6 cm/s
Compound 4: the middle estimate sits 9.5-fold (0.98 log units) below what was measured, outside the stated range (above it).
By their numbers in this assay, from the lowest: compounds 2 and 3 (each within the scatter of the next); then compounds 4 and 1 (each within the scatter of the next).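

Going by these compounds alone, this is the first single-place step measured: in this assay, phenyl in place of benzyl on an aromatic carbon gives a 10-fold higher number from compound 2 to compound 4 (1.01 log units; beyond the scatter) with the rest of the molecule unchanged. This position, meta to a fused ring and para to a fused ring, is therefore not neutral in this read-out. The step is large even though entering and leaving groups each hold one six-membered aromatic ring of carbon only, with no hydrogen-bond donors or acceptors, and go only from 7 heavy atoms to 6.

On these data alone, whether a carboxylic acid, a morpholine or a longer alkyl chain on this aromatic carbon would read like phenyl or like benzyl remains open, as does whether the step carries over to other side chains on the shared core. Within the data shown here, nothing measured so far accounts for the size of this step.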